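The compounds below may be only part of what the source reports. "The series", "measured", "known", "first", "only" and "open" are said of these compounds alone.

Working notes on the series. The assay is a toxicity assay on NIH3T3 cells (Mus musculus) for cytotoxicity, read by resazurin assay; a lower number here means that less compound is needed, a higher number that more compound is needed for the effect. Compound 1 `COC(=O)c1ccc(NCc2cncn2Cc2ccc(N)cc2)cc1-c1ccccc1` was tested, and for compound 1 the assay reports a limit rather than a number, > 10000 nM. Compound 2 `COC(=O)c1ccc(NCc2cncn2Cc2ccccc2OC)cc1-c1ccccc1` has no result in this assay, reported as "not determined" (no result reported). So compound 2 stands without a single number among the values shown; the only other value in the set is a limit, (the limit of > 10000 nM in this assay, at which 1 of the 2 values shown sits), and no step between measured compounds can be drawn from it.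

The unmeasured compound 3 `COC(=O)c1ccc(NCc2cncn2Cc2cccc(C#N)c2)cc1-c1ccccc1` differs from compound 2 by one change: 3-cyanophenyl in place of 2-methoxyphenyl on a saturated chain carbon bound to an aromatic nitrogen. The change swaps one eight-heavy-atom aromatic substituent for another, with no change in donor or acceptor count and no net charge introduced.

Expectation: with no measured step in this assay and the one available value being a limit, compound 3 is expected to behave like the rest of the set, most likely returning a limit again rather than a number. For compound 3 the half-maximal effective concentration in this assay is estimated at 15000 nM, within a range of 4000 nM to 60000 nM.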

Compound 3, half-maximal effective concentration: > 10000 nM
Compound 3 was reported as a limit (the forecaster's own chance of this, stated with the estimate: 70%); the middle value is on the limit's open side.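

Compound 1 and compound 3 are both reported only as limits in this assay, so no step between them can be read: the limit of > 10000 nM in this assay, at which 2 of the 3 values shown sit.

The compounds shown leave open whether any group on a saturated chain carbon bound to an aromatic nitrogen gives a single number in this assay, rather than a limit.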